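The source may hold more compounds than are shown below. What is called first, only, known or untested is meant among the compounds shown, and "the series" means these compounds.

Compounds measured in a functional assay on WI-38 VA13 cells (Homo sapiens) for cytotoxicity; a higher number here means that more compound is needed for the effect, a lower number that less compound is needed:

Compound 1: `CCCC(C)C(=O)Nc1ccc2nc(NC(=O)C3CCCCC3)sc2c1` — 0.14 ug/mL
Compound 2: `Cc1cccc(C)c1NC(=O)Nc1ccc2nc(NC(=O)C3CCCCC3)sc2c1` — 0.56 ug/mL
Compound 3: `CCCC(=O)Nc1nc2ccc(NC(=O)c3c(Cl)cccc3Cl)cc2s1` — 0.01 ug/mL

Compound 3 gives the lowest number of the three in this assay, and its gaps to compound 1 and to compound 2 are both beyond the scatter, so it needs the least compound for the effect among those measured. Compound 4, `COc1ccc(Nc2nc3ccc(NC(=O)c4c(Cl)cccc4Cl)cc3s2)cc1`, is not yet measured. It differs from compound 3 in one place: 4-methoxyphenyl in place of propylcarbonyl on a nitrogen on an aromatic ring.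

For the measured compounds named here, only one measured step exists, and it sits on the other side of the shared core: a 4.0-fold higher number from compound 1 to compound 2 (0.60 log units; beyond the scatter). That step also replaced a chain-bearing carbonyl substituent with a ring-bearing amino substituent, and the number rose modestly. Going by the values given here, no measured pair changes the nitrogen on the aromatic ring itself, so the step to compound 4 has no direct precedent. Taking the one step as a rough guide, a modest rise in the number is expected in this assay, with wide uncertainty. For compound 4 the estimate is 0.05 ug/mL, with a range from 0.01 ug/mL to 0.3 ug/mL, meaning an expected step of a 5.0-fold higher number from compound 3 to compound 4 (0.70 log units; beyond the scatter).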

Compound 4, half-maximal effective concentration: 0.87 ug/mL
Beside the measured number, compound 4's estimate is 17-fold (1.24 log units) below it, and the stated range ends below it.
By their numbers in this assay, from the lowest: compound 3; then compound 1; then compounds 2 and 4 (each within the scatter of the next).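

In this assay, for the compounds shown here, putting 4-methoxyphenyl in place of propylcarbonyl on a nitrogen on an aromatic ring gives an 87-fold higher number from compound 3 to compound 4 (1.94 log units; beyond the scatter) and is a large step, which shows that the number depends strongly on what sits at this place, a place that no earlier pair had changed. The one earlier step, a 4.0-fold higher number from compound 1 to compound 2 (0.60 log units; beyond the scatter) on the other side of the shared core, was modest, so among the compounds shown both single changes that bring in an aromatic ring for an open chain raise the number, and neither goes against this, though two steps at two different places make only a thin pattern. Nothing available here accounts for the size of the new step.

The change takes away the carbonyl and brings in the aromatic ring in a single move, so the compounds shown leave open which of the two goes with the rise in the number. A benzoyl group on the same nitrogen would keep the carbonyl and carry a ring, while a plain phenyl group or a butyl chain there would show how much the methoxy group and the ring each contribute.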